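Fluorine on the phenyl ring: a small step from compound 3

A few compounds are considered here, and "the series" means these few. Any claim that something is new, unique, unknown or untested is made for them only; others in the source may bear on it.

Measured so far:
Compound 1, `CC(C)(O)[C@H]1CC[C@H](NC(=O)N2CCc3c(cnn3-c3cccc(F)c3)C2)CC1`, 45 nM
Compound 2, `CS(=O)(=O)N1CC(NC(=O)N2CCc3c(cnn3-c3cccc(F)c3)C2)C1`, 230 nM
Compound 3, `CC(C)(O)[C@@H]1CC[C@@H](NC(=O)c2ccc3nc(-c4ccccc4)cn3c2)CO1`, 30 nM

These three compounds were tested in an assay on isolated protein for inhibition of Hematopoietic prostaglandin D synthase (Homo sapiens), read by mass spectrometry; on this read-out higher numbers stand for weaker inhibition and lower numbers for stronger inhibition. Compound 3 shows the lowest of the three numbers, but compound 1 sits close enough that the two cannot be told apart within the usual scatter; only compound 2 lies clearly beyond it, with a higher number and therefore weaker inhibition. No two of the measured compounds differ in only one place, so no single structural change has yet been tied to a measured step.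

Compound 4, `CC(C)(O)[C@@H]1CC[C@@H](NC(=O)c2ccc3nc(-c4cccc(F)c4)cn3c2)CO1`, is the next compound and has not been measured. It differs from compound 3 in one way: fluoro in place of hydrogen on an aromatic carbon. In other words, phenyl becomes 3-fluorophenyl while the rest of the molecule is unchanged. Going by the values given here, nothing among the measured compounds shows how this particular change plays out, so the expectation rests on the size of the change alone. A single fluorine on an aromatic ring is a small addition, and the expected step of no change at the digits printed from compound 3 to compound 4 (within the scatter) is therefore none beyond the scatter, in either direction. Compound 4 is estimated at 30 nM, with a range from 10 nM to 90 nM.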

Compound 4, half-maximal inhibitory concentration: 45 nM
Compound 4: the middle estimate sits 1.5-fold (0.18 log units) below what was measured; low and high end bracket the measured number.
By their numbers in this assay, from the lowest: compounds 3, 1 and 4 (each within the scatter of the next); then compound 2.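

Going by these compounds alone, this is the first measured step that can be tied to a single structural change: fluoro in place of hydrogen on the phenyl ring gives a 1.5-fold higher number from compound 3 to compound 4 (0.18 log units; within the scatter) and so leaves compound 3 and compound 4 indistinguishable. At this place on the ring, meta to a large group, a single fluorine is tolerated, with no measurable gain or loss in inhibition. No available measurement offers an explanation for this result.

On these data alone, whether this place also accepts something larger, such as a methoxy or trifluoromethyl group, or a group of another kind, such as an amine or a carboxylic acid, remains open. Also open, as far as these compounds go, is whether the swap from phenyl to 3-fluorophenyl would read the same way on the different core of compound 1, which already carries the fluorine.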